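Aryl swap on the amidine nitrogen: compound 2 to compound 4

The compounds below may be only part of what the source reports. "The series", "measured", "known", "first", "only" and "open" are said of these compounds alone.

Three members of this series carry the same core with a varied aryl group on the amine nitrogen. Compound 1 `Cc1ccc(S(=O)(=O)/N=C(/CCNC2=CC(=O)c3ccccc3C2=O)Nc2ccccc2[N+](=O)[O-])cc1` gives 3310 nM in a functional assay on HeLa cells (Homo sapiens) for cytotoxicity, read by MTT assay, with a stated time of 48 h; a lower number here means a stronger inhibitor, a higher number a weaker inhibitor. Compound 2 `Cc1ccc(S(=O)(=O)/N=C(/CCNC2=CC(=O)c3ccccc3C2=O)Nc2cccc(C(F)(F)F)c2)cc1` gives 77600 nM in this assay, and compound 3 `COc1ccc(N/C(CCNC2=CC(=O)c3ccccc3C2=O)=N\S(=O)(=O)c2ccc(C)cc2)c(OC)c1` gives 67600 nM in this assay. Compound 2 shows the highest number of the three; its nearest neighbour is compound 3, as a 1.1-fold lower number from compound 2 to compound 3 (0.06 log units; within the scatter), and its furthest is compound 1, as a 23-fold higher number from compound 1 to compound 2 (1.37 log units; beyond the scatter).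

Compound 4 `Cc1ccc(S(=O)(=O)/N=C(/CCNC2=CC(=O)c3ccccc3C2=O)Nc2ccc(Cl)cc2Cl)cc1` is not yet measured. Relative to compound 2 the change is 2,4-dichlorophenyl in place of 3-(trifluoromethyl)phenyl on an amine nitrogen. Among the compounds with values here, the steps that bear on it are those away from the 2-nitrophenyl of compound 1: a 23-fold higher number from compound 1 to compound 2 (1.37 log units; beyond the scatter) and a 20-fold higher number from compound 1 to compound 3 (1.31 log units; beyond the scatter), both large, while the two non-nitro aryls sit together, as a 1.1-fold lower number from compound 2 to compound 3 (0.06 log units; within the scatter). Compound 4 carries neither the nitro group nor any other feature that the measured steps single out, so no step beyond the scatter is expected in this assay; the expected step is a 1.4-fold lower number from compound 2 to compound 4 (0.15 log units; within the scatter). Compound 4 is therefore estimated at 55000 nM, with a range from 12000 nM to 200000 nM.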

Compound 4, half-maximal inhibitory concentration: 20500 nM
Compound 4: middle estimate off by 2.7-fold (0.43 log units), on the high side, and the stated range covers the measured number.
By their numbers in this assay, from the lowest: compound 1; then compound 4; then compounds 3 and 2 (each within the scatter of the next).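

In this assay the aryl groups without a nitro substituent no longer sit together at this amine nitrogen: 2,4-dichlorophenyl gives a 3.8-fold lower number from compound 2 to compound 4 (0.58 log units; beyond the scatter) and a 3.3-fold lower number from compound 3 to compound 4 (0.52 log units; beyond the scatter), a separation that compound 2 and compound 3 alone did not show. The 2-nitrophenyl of compound 1 still holds the lowest number of the four, with a 6.2-fold higher number from compound 1 to compound 4 (0.79 log units; beyond the scatter), so among these compounds the position reads as graded rather than as a split between nitro and everything else. Nothing available here accounts for this order of the aryl groups.

From the compounds shown here alone, whether a single chlorine on the phenyl ring would give the same number as the two in compound 4 remains open. So does the outcome with a pyridyl ring, or with a phenyl ring carrying an amine or a carboxylic acid, on this nitrogen.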